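The compounds below may be only part of what the source reports. "The series", "measured", "known", "first", "only" and "open" are said of these compounds alone.

Measured so far in a functional assay on the whole organism (stomach) with Rattus norvegicus as the target; on this read-out lower numbers stand for an effect already at smaller amounts and higher numbers for an effect only at larger amounts of compound:
- compound 1 `CC(C)C/N=C(\S)NCCCCn1nc(-c2ccccc2)ccc1=O`: its result is a limit of the assay, > 100 mg/kg.
- compound 2 `C/N=C(\NC#N)NCCCCn1nc(-c2ccccc2)ccc1=O`: 32.4 mg/kg.
- compound 3 `C/N=C(\S)NCCCCn1nc(-c2ccccc2)ccc1=O`: 28.9 mg/kg.

Compound 3 carries the lowest of the two numbers shown, but its nearest neighbour is compound 2 and the two sit within the scatter: a 1.1-fold lower number from compound 2 to compound 3 (0.05 log units; within the scatter). The steps that clearly moved the read-out both start from compound 1: an at least 3.0-fold lower number from compound 1 to compound 2 (0.48 log units; beyond the scatter) and an at least 3.4-fold lower number from compound 1 to compound 3 (0.53 log units; beyond the scatter). Both of these rest on a limit rather than a number (the limit of > 100 mg/kg in this assay, at which 1 of the 3 values shown sits).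

Compound 4 `C/N=C(/NC#N)N(C)CCCCn1nc(-c2ccccc2)ccc1=O` is not yet measured. Compared with compound 3 the change is a group of 8 heavy atoms (4 carbon, 4 nitrogen; no ring) in place of a group of 5 heavy atoms (2 carbon, 2 nitrogen, 1 sulfur; no ring), on a saturated chain carbon, four bonds along the chain from an aromatic nitrogen. Among the compounds with values here, the measured step that bears most directly on this exchange is a 1.1-fold lower number from compound 2 to compound 3 (0.05 log units; within the scatter), which stayed within the scatter; the remaining part of the exchange has no measured counterpart. On this basis no step beyond the scatter is expected, with a small shift toward a higher number as the more likely direction. For compound 4 the estimate in this assay is 38 mg/kg, expected to fall between 13 mg/kg and 100 mg/kg. This estimate corresponds to an expected step of a 1.3-fold higher number from compound 3 to compound 4 (0.12 log units; within the scatter).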

Compound 4, dose for half-maximal effect: > 100 mg/kg
Compound 4 gave a limit, no number; the forecaster's own chance of this, stated with the estimate: 15%; at least 2.6-fold (0.42 log units) between middle value and limit.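

In this assay, the exchange between compound 2 and compound 3 stayed within the scatter, so neither compound showed that this part of the molecule could shift the read-out. The group of 8 heavy atoms, on a saturated chain carbon, four bonds along the chain from an aromatic nitrogen, does shift it: an at least 3.4-fold higher number from compound 3 to compound 4 (0.53 log units; beyond the scatter), and an at least 3.0-fold higher number from compound 2 to compound 4 (0.48 log units; beyond the scatter). Both steps give only a minimum size, and the step between compound 1 and compound 4 cannot be read, as these results are limits rather than numbers: the limit of > 100 mg/kg in this assay, at which 2 of the 4 values shown sit.

The compounds shown do not separate the contribution of each part of the group of 8 heavy atoms, and the true size of the shift stays open. On these data alone, how a simple amine or a longer chain would read out at this place also remains unknown.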